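Swapping Chloro for Trifluoromethyl on the Aromatic Ring

The compounds below may be only part of what the source reports. "The series", "measured", "known", "first", "only" and "open" are said of these compounds alone.

Compound 1 `CC(C)(C)NS(=O)(=O)c1ccc(-c2sc(C(=O)N[C@H]3C[C@H](C(=O)O)C3)nc2CC2CCCCC2)c(Cl)c1` was run in an ADME assay on microsomes (Rattus norvegicus) for metabolic stability (on this read-out lower numbers stand for a shorter-lived compound and higher numbers for a longer-lived compound), and gives 1.22 h there. Among the compounds with values here, this is the higher of the two numbers measured so far. The other measured compound, compound 2 `CC(C)(O)CNC(=O)c1nc(CC2CCCCC2)c(-c2ccc(S(=O)(=O)NC(C)(C)C)c(Cl)c2C(F)F)s1`, gives 0.233 h in this assay, a number beyond the usual scatter from compound 1. Within the data shown here, compound 2 differs from compound 1 in several places at once, so the two values show only that these compounds sit well apart.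

Compound 3 `CC(C)(C)NS(=O)(=O)c1ccc(-c2sc(C(=O)N[C@H]3C[C@H](C(=O)O)C3)nc2CC2CCCCC2)c(C(F)(F)F)c1` has not yet been measured. It differs from compound 1 in one place: trifluoromethyl in place of chloro on an aromatic carbon, in words a trifluoromethyl in place of chloro on an aromatic carbon. Among the measured compounds shown here, no measured pair shows the effect of this exchange on its own. The step of a 1.1-fold higher number from compound 1 to compound 3 (0.03 log units; within the scatter) is expected to stay within the usual scatter, in no clear direction. Compound 3 is therefore estimated at 1.3 h, with a range from 0.5 h to 3.2 h around it.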

Compound 3, half-life in the Rattus norvegicus assay: 2.33 h
Compound 3: middle estimate off by 1.8-fold (0.25 log units), on the low side; the range from low to high includes it.
By their numbers in the Rattus norvegicus assay, from the lowest: compound 2; then compounds 1 and 3 (each within the scatter of the next).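

At this position, on an aromatic carbon ortho to a large group, a measured pair now shows the exchange on its own: in the Rattus norvegicus assay trifluoromethyl in place of chloro gives a 1.9-fold higher number from compound 1 to compound 3 (0.28 log units; within the scatter), so a group of 4 heavy atoms can stand where 1 heavy atom stood without a clear shift in half-life. In a physicochemical assay for solubility, read by HPLC, in phosphate buffer, measured as thermodynamic solubility, with a stated time of 5 days, at pH 2, tested at 10 mM (on this read-out lower numbers stand for lower solubility and higher numbers for higher solubility), compound 1 gives only a limit, not a number, of < 1000 nM. In the physicochemical assay compound 3 likewise gives only a limit, of < 4000 nM.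

These two limits cannot be read as a step in solubility, and nothing shown gives a reason for the half-life result. Still open, from the compounds shown here alone, is what a methyl or a nitrile would do at this place on the ring, and whether the same exchange gives a similar step in other compounds.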